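From ethylsulfonyl to methylsulfonyl at the clearance limit

This account rests on a few compounds, and the source may have more. Where it says the series, first, only, none or still open, it means among the compounds named here.

Of the compounds shown here, two have been measured so far, and neither gives an exact number. In an ADME assay on microsomes from liver (Homo sapiens) for metabolic stability, read by LC-MS, using NADPH, with stated times of 10 min and 30 min (on this read-out higher numbers stand for fast clearance and lower numbers for slow clearance), compound 1 (`CCC(=O)N[C@@H]1CCCc2c1cncc2N1C(=O)c2ccc(Cl)cc2[C@@H]1CC`) gives < 3.5 mL/min/kg and this is a limit of the assay, not a number. Compound 2 (`CCS(=O)(=O)N[C@@H]1CCCc2c1cncc2N1Cc2cc(Cl)ccc2C1=O`) gives < 3.5 mL/min/kg and this too is a limit, not a number. Compound 2 therefore stands at the limit of < 3.5 mL/min/kg in this assay, at which 2 of the 2 values shown sit, and has no exact value.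

Compound 3 (`CS(=O)(=O)N[C@@H]1CCCc2c1cncc2N1Cc2cc(Cl)ccc2C1=O`) has hydrogen in place of methyl on a saturated chain carbon bound to a sulfonyl sulfur, so ethylsulfonyl becomes methylsulfonyl (hydrogen in place of methyl on a saturated chain carbon bound to a sulfonyl sulfur). Going by the values given here, no measured pair shows this change in this assay and no step beyond the usual scatter is expected. The estimated step is a step that the limit leaves unreadable from compound 2 to compound 3 and it is expected to stay within that scatter. For compound 3 the estimated clearance is 3 mL/min/kg with an expected range of 1.5 mL/min/kg to 6 mL/min/kg and the result may again be only a limit.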

Compound 3, clearance: < 3.5 mL/min/kg
Compound 3: a limit, no number (the forecaster's own chance of this, stated with the estimate: 75%); the middle value is on the limit's open side.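

Compound 2 and compound 3 both give a limit rather than a number, so no step can be read between them for the change from ethylsulfonyl to methylsulfonyl: the limit of < 3.5 mL/min/kg in this assay, at which 3 of the 3 values shown sit.

The compounds shown leave open how slow the clearance of each really is, and whether that change alters it at all.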